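The source may report more compounds than this note shows. Statements on the series, on what has been measured and on what is new or still open speak of the compounds shown alone.

Compound 3, `COc1cc2ncnc(Nc3cccc(Br)c3)c2cc1OCCCn1ccnc1[N+](=O)[O-]`, sits in the upper part of the numbers measured in a functional assay on HT-29 cells (Homo sapiens) for cytotoxicity, read by sulforhodamine B assay, with a stated time of 72 h; on this read-out lower numbers stand for stronger inhibition and higher numbers for weaker inhibition: compound 3 gives 4010 nM. Its nearest neighbour is compound 2, `COc1cc2ncnc(Nc3ccc(F)c(Cl)c3)c2cc1OCCCCCn1ccnc1[N+](=O)[O-]`, which in this assay gives 5590 nM, a number within the scatter of that of compound 3. Compound 1, `COc1cc2ncnc(Nc3ccc(F)c(Cl)c3)c2cc1OCCCCn1ccnc1[N+](=O)[O-]`, gives in this assay 1620 nM, a lower number that lies beyond the scatter from compound 3. The only single-change step among these three, a 3.5-fold higher number from compound 1 to compound 2 (0.54 log units; beyond the scatter), concerns the chain that links the shared core to the nitroimidazole, not the aniline.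

Compound 4, `C#Cc1cccc(Nc2ncnc3cc(OC)c(OCCCn4ccnc4[N+](=O)[O-])cc23)c1`, differs from compound 3 by ethynyl in place of bromo on an aromatic carbon. Among the compounds with values here, no measured pair shows this exchange, so nothing directly bears on its effect in this assay. With no guidance from the measured steps, the expectation for compound 4 is a number close to that of compound 3, a step of a 1.3-fold lower number from compound 3 to compound 4 (0.13 log units; within the scatter) that stays within the scatter. Compound 4 is therefore estimated at 3000 nM, with a range from 1000 nM to 9000 nM.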

Compound 4, half-maximal inhibitory concentration: 5530 nM
For compound 4 the middle estimate is 1.8-fold (0.27 log units) below the measured one; measured number inside the range.
By their numbers in this assay, from the lowest: compound 1; then compounds 3, 4 and 2 (each within the scatter of the next).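

Going from 3-bromophenyl to 3-ethynylphenyl gives a 1.4-fold higher number from compound 3 to compound 4 (0.14 log units; within the scatter) in this assay, so this is the first reading at this place on the aniline, which the earlier chain step could not give. At this position, the two groups cannot be told apart in this cytotoxicity read-out, although ethynyl brings two heavy atoms and a triple bond where bromo has a single heavy atom. No measurement at hand accounts for this result.

From the compounds shown here alone, whether a carboxylic acid or an amine on the same aromatic carbon would also stay within the scatter of bromo remains open. Going by these compounds, it is also open whether ethynyl in place of bromo would give the same result with the longer chains and the different aniline of compound 1 and compound 2.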